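Swapping the ring on a short-lived compound

This account rests on a few compounds, and the source may have more. Where it says the series, first, only, none or still open, it means among the compounds named here.

Measured half-lives:
- compound 1 `COC[C@H](NC(=O)[C@H](CSC)NC(=O)c1cc(C)on1)C(=O)N[C@@H](CC(C)C)C(=O)[C@@]1(C)CO1`: 1.11 h
- compound 2 `CSC[C@H](NC(=O)c1cc(C)on1)C(=O)N[C@@H](CSC)C(=O)N[C@@H](CC(C)C)C(=O)[C@@]1(C)CO1`: 0.132 h
- compound 3 `CSC[C@H](NC(=O)c1cc(C)on1)C(=O)NCC(=O)N[C@@H](CC(C)C)C(=O)[C@@]1(C)CO1`: 0.373 h

In an ADME assay on microsomes from liver (Rattus norvegicus) for metabolic stability (a higher number here means that the compound lasts longer, a lower number that the compound disappears faster), compound 2 has the lowest number of the three, at 0.132 h, so it disappears fastest. Compound 4 `CSC[C@H](NC(=O)c1cnc(C)s1)C(=O)N[C@@H](CSC)C(=O)N[C@@H](CC(C)C)C(=O)[C@@]1(C)CO1` has not yet been measured. It differs from compound 2 as follows: 2-methyl-1,3-thiazol-5-yl in place of 5-methyl-1,2-oxazol-3-yl on a carbonyl carbon. Put simply, 2-methyl-1,3-thiazol-5-yl stands in place of 5-methyl-1,2-oxazol-3-yl on a carbonyl carbon.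

Within the data shown here, none of the measured steps touches this ring. All of them change a group on a saturated chain carbon, so they bear on the question only indirectly. They show that this assay can respond to single changes elsewhere in these molecules: an 8.4-fold lower number from compound 1 to compound 2 (0.92 log units; beyond the scatter), a 3.0-fold lower number from compound 1 to compound 3 (0.47 log units; beyond the scatter) and a 2.8-fold higher number from compound 2 to compound 3 (0.45 log units; beyond the scatter). Among the measured compounds shown here, no measured pair shows what this ring exchange does, so no direction can be argued from the data. The expected step is therefore a 1.0-fold lower number from compound 2 to compound 4 (0.01 log units; within the scatter), with nothing beyond the scatter anticipated. Compound 4 is estimated at 0.13 h, with an expected range of 0.06 h to 0.3 h.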

Compound 4, half-life: 0.123 h
For compound 4 the middle estimate is 1.1-fold (0.02 log units) above the measured one, and the stated range covers the measured number.
By their numbers in this assay, from the lowest: compounds 4 and 2 (each within the scatter of the next); then compound 3; then compound 1.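

In this assay, among these compounds, the first measured exchange of the ring on this carbonyl carbon, 2-methyl-1,3-thiazol-5-yl in place of 5-methyl-1,2-oxazol-3-yl, gives a 1.1-fold lower number from compound 2 to compound 4 (0.03 log units; within the scatter) and so no readable difference in half-life. Sulfur stands in the new ring where the old one has oxygen, yet at this place, with the rest of compound 2 unchanged, the assay does not separate the two rings, whereas each earlier step on a saturated chain carbon lay beyond the scatter. Nothing available explains why the two rings read alike.

As far as these compounds go, whether the same exchange would also read alike in compound 1 or compound 3, which carry other chain groups, remains open. Also open, from the compounds shown here alone, is what a phenyl ring, or a ring bearing an amine or a carboxylic acid, would do on the same carbonyl carbon.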